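Amide aryl variation on the shared core

This account rests on a few compounds, and the source may have more. Where it says the series, first, only, none or still open, it means among the compounds named here.

The series keeps the shared core of compound 1 `Cc1nc(C(=O)Nc2ccc(Cl)c(-c3nnc4c(Cl)cccn34)c2)cs1` and varies the group on the carbonyl carbon of the amide. In a functional assay on HeLa cells (Homo sapiens) for antiproliferative activity, read by MTT assay, with a stated time of 72 h (on this read-out higher numbers stand for weaker inhibition and lower numbers for stronger inhibition), compound 1 gives 79800 nM. Compound 2 `O=C(Nc1ccc(Cl)c(-c2nnc3c(Cl)cccn23)c1)c1ccccc1Cl` carries a 2-chlorophenyl on the carbonyl carbon; in this assay compound 2 gives > 100000 nM, which is a limit of the assay and not a number. Compound 3 `O=C(Nc1ccc(Cl)c(-c2nnc3c(Cl)cccn23)c1)c1ccc(Cl)cc1` carries a 4-chlorophenyl; in this assay compound 3 gives > 100000 nM, again a limit. Compound 3 thus sits at the limit, with an at least 1.2-fold higher number from compound 1 to compound 3 (0.09 log units; that floor lies within the scatter) and, for the 2-chlorophenyl isomer, an at least 1.2-fold higher number from compound 1 to compound 2 (0.09 log units; that floor lies within the scatter); the step that the two limits leave unreadable from compound 2 to compound 3 cannot be read because of the limit of > 100000 nM in this assay, at which 2 of the 3 values shown sit.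

Compound 4 `CS(=O)(=O)c1cccc(C(=O)Nc2ccc(Cl)c(-c3nnc4c(Cl)cccn34)c2)c1` is not yet measured. Its change from compound 3 is 3-(methylsulfonyl)phenyl in place of 4-chlorophenyl on a carbonyl carbon. For the measured compounds named here, the steps that bear on it are the three aryl swaps just named, all of which leave the number at or near the limit; none reads as a gain beyond the scatter, and nothing shows what the 3-(methylsulfonyl)phenyl does. For compound 4 a step of a number no higher from compound 3 to compound 4 (the limit leaves the size open) is therefore expected, that is, no change beyond the scatter, with a fair chance that only a limit is again reported. Compound 4 is estimated at 100000 nM, within 40000 nM to 300000 nM.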

Compound 4, half-maximal inhibitory concentration: 86400 nM
The estimate for compound 4 lay 1.2-fold (0.06 log units) above the measured number, within the range that was stated.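

In this assay compound 4 gives a number and not a limit, so a carbon-only aromatic ring on the carbonyl carbon can read inside the assay range, which the chlorophenyl compounds did not show, and the 3-(methylsulfonyl)phenyl, with its hydrogen-bond acceptors, lands with the 2-methyl-1,3-thiazol-4-yl at a 1.1-fold higher number from compound 1 to compound 4 (0.03 log units; within the scatter). Against the two chlorophenyl groups only floors can be given, at an at least 1.1-fold lower number from compound 3 to compound 4 (0.06 log units; that floor lies within the scatter) and an at least 1.1-fold lower number from compound 2 to compound 4 (0.06 log units; that floor lies within the scatter), so neither swap reads as a gain beyond the scatter. These two steps have an open size and the step between the two chlorophenyl compounds still cannot be read, as the values of compound 2 and compound 3 are limits and not numbers: the limit of > 100000 nM in this assay, at which 2 of the 4 values shown sit.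

The compounds shown leave open whether an aminomethylphenyl, a carboxylic acid or a longer alkyl chain on the carbonyl carbon would move the number beyond the scatter. They also leave open how much of this level of the read-out belongs to the shared core, which stays the same in every compound shown.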